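This account rests on a few compounds, and the source may have more. Where it says the series, first, only, none or still open, it means among the compounds named here.

In an ADME assay on HEK293 cells (Homo sapiens) for cytotoxicity, read by luminescence, with a stated time of 72 h (on this read-out higher numbers stand for an effect only at larger amounts of compound and lower numbers for an effect already at smaller amounts), the three measured compounds give the following results:

compound 1 `CCOC(=O)c1c(-c2cc(F)cc(OC)c2)[nH]c2cc(OC)ccc2c1=O` gives > 22000 nM, which is a limit of this assay rather than a number.
compound 2 `CCOC(=O)c1c(-c2cccc(OC)c2)[nH]c2cc(OC)ccc2c1=O` gives > 22000 nM, again a limit and not a number.
compound 3 `CCOC(=O)c1c(-c2cccc(F)c2)[nH]c2cc(OC)ccc2c1=O` gives > 22000 nM, also a limit and not a number.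

All three compounds share one core and differ only in the groups on the pendant phenyl ring. Compound 2 and compound 3 differ by methoxy in place of fluoro on an aromatic carbon. Compound 3 becomes compound 1 by methoxy in place of hydrogen on an aromatic carbon, and that change made a step that the two limits leave unreadable from compound 3 to compound 1. The reason is the limit of > 22000 nM in this assay, at which 3 of the 3 values shown sit, so no compound shows a measurable effect within the range the assay covers.

The not yet measured compound 4 `CCOC(=O)c1c(-c2cc(OC)cc(OC)c2)[nH]c2cc(OC)ccc2c1=O` arises from compound 2 by methoxy in place of hydrogen on an aromatic carbon. For the measured compounds named here, this is the same kind of change as the one from compound 3 to compound 1, though not the same: in compound 3 the entering methoxy sits meta to a fluoro group, whereas in compound 2 it sits meta to a methoxy group.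

Since compound 3 and compound 1 both sit at the limit, and compound 2 does too, compound 4 is expected to follow, with an estimated step that the limit leaves unreadable from compound 2 to compound 4. The estimated value for compound 4 in this assay is 30000 nM, and most probably the assay will again report only its limit.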

Compound 4, half-maximal effective concentration: > 22000 nM
Compound 4 ended at the assay's limit (the forecaster's own chance of this, stated with the estimate: 85%); the middle value is on the limit's open side.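

The steps from compound 2 and from compound 1 to compound 4 cannot be read in this assay, because every compound rests on the same limit and not on a number: the limit of > 22000 nM in this assay, at which 4 of the 4 values shown sit.

The compounds shown leave open at what concentration any of these four would begin to harm the cells, and whether any change on the pendant phenyl ring would bring such an effect into the assay's range.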